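A few compounds are considered here, and "the series" means these few. Any claim that something is new, unique, unknown or untested is made for them only; others in the source may bear on it.

Measured so far in a functional assay on A549 cells (Homo sapiens) for cytotoxicity, read by MTT assay, with a stated time of 72 h; on this read-out higher numbers stand for weaker inhibition and lower numbers for stronger inhibition:
Compound 1 `COc1ccc(-c2ccnc(Nc3ccc(C(N)=O)cc3)n2)cc1`: 5300 nM
Compound 2 `COC(=O)c1ccc(Nc2nccc(-c3ccc(OC)cc3)n2)cc1`: 6000 nM

In this assay, among the measured compounds shown here, compound 1, at 5300 nM, lies within the scatter of compound 2, the only other measured compound. Compound 3 `Cc1csc(-c2ccnc(Nc3ccc(C(N)=O)cc3)n2)c1` carries 4-methylthiophen-2-yl in place of 4-methoxyphenyl on an aromatic carbon of compound 1: 4-methylthiophen-2-yl in place of 4-methoxyphenyl on an aromatic carbon. For the measured compounds named here, the sole measured step, a 1.1-fold higher number from compound 1 to compound 2 (0.05 log units; within the scatter), lies within the scatter but changes another place, so it says little here. Going by the values given here, no measured step touches this place, so no direction can be argued and no step beyond the scatter is expected. The expected change is a 1.1-fold lower number from compound 1 to compound 3 (0.03 log units; within the scatter). For compound 3 the estimated value is 5000 nM, with an expected range of 1500 nM to 15000 nM.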

Compound 3, half-maximal inhibitory concentration: 30000 nM
Compound 3: the middle estimate sits 6.0-fold (0.78 log units) below what was measured; measured number above the stated range.
By their numbers in this assay, from the lowest: compounds 1 and 2 (each within the scatter of the next); then compound 3.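

In this assay, this position on the shared core proves sensitive to the group it carries: 4-methylthiophen-2-yl in place of 4-methoxyphenyl gives a 5.7-fold higher number from compound 1 to compound 3 (0.75 log units; beyond the scatter). The earlier change on the carbonyl carbon, a 1.1-fold higher number from compound 1 to compound 2 (0.05 log units; within the scatter), had shown no step beyond the scatter, so this is the first such step among the compounds shown. Nothing available explains why this exchange weakens inhibition. What a plain phenyl or an unsubstituted thiophen-2-yl would give here stays open, so the compounds shown do not separate the effect of the ring from that of its substituent.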